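Swapping 4-methylphenyl for 2-methylphenyl

The compounds below may be only part of what the source reports. "The series", "measured", "known", "first", "only" and "open" are said of these compounds alone.

Measured in a functional assay on XF498 cells (Homo sapiens) for cytotoxicity; a higher number here means a weaker inhibitor, a lower number a stronger inhibitor:
- compound 1 `COc1ccc(-c2cc3cc(C)ccc3c(N3CCN(C)CC3)n2)cc1`: 7410 nM
- compound 2 `Cc1ccc(-c2cc3cc(C)ccc3c(N3CCN(C)CC3)n2)cc1`: 4470 nM

The two values of compound 1 and compound 2 lie within the scatter of each other, so neither stands apart. Compound 3 `Cc1ccc2c(N3CCN(C)CC3)nc(-c3ccccc3C)cc2c1` has the same atoms as compound 2, joined differently: 2-methylphenyl in place of 4-methylphenyl on an aromatic carbon. Among the measured compounds shown here, the only measured step that bears on this is a 1.7-fold lower number from compound 1 to compound 2 (0.22 log units; within the scatter), methyl in place of methoxy on an aromatic carbon. For the measured compounds named here, that step is small, but no measured compound carries 2-methylphenyl, so the evidence is thin. In this assay, no change beyond the scatter is expected, and no direction is favoured. The estimated step is a 1.1-fold higher number from compound 2 to compound 3 (0.05 log units; within the scatter). The estimate for compound 3 is 5000 nM, with an expected range from 2000 nM to 12500 nM.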

Compound 3, half-maximal inhibitory concentration: 6610 nM
Compound 3: middle estimate off by 1.3-fold (0.12 log units), on the low side, and the stated range covers the measured number.
By their numbers in this assay, from the lowest: compounds 2, 3 and 1 (each within the scatter of the next).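

In this assay, moving the methyl from 4-methylphenyl to 2-methylphenyl gives (a 1.5-fold higher number from compound 2 to compound 3 (0.17 log units; within the scatter)), and putting 2-methylphenyl in place of 4-methoxyphenyl gives (a 1.1-fold lower number from compound 1 to compound 3 (0.05 log units; within the scatter)). At this position, next to the ring nitrogen, changing where the methyl sits on the phenyl ring has therefore produced no step beyond the scatter, just as changing methoxy to methyl did not. No supporting data explain this result. Still open, from the compounds shown here alone, is whether 3-methylphenyl, or a phenyl ring carrying an amine or a carboxylic acid, would move the number beyond the scatter.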